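Aryl swap on the propenyl chain: compound 3 to compound 4

The source may hold more compounds than are shown below. What is called first, only, known or untested is meant among the compounds shown, and "the series" means these compounds.

The series is tested in a functional assay on HL-60 cells (Homo sapiens) for cytotoxicity, read by WST assay, with a stated time of 48 h; on this read-out higher numbers stand for weaker inhibition and lower numbers for stronger inhibition. Compound 1 `COc1ccc(/C=C/C[C@H]2C[C@H]([C@H](O)c3ccc(OC)c(OC)c3)CO[C@@H]2c2ccc(OC)c(OC)c2)cc1OC` gives 23500 nM. Compound 2 `CCCCCC/C=C/C[C@H]1C[C@@H]([C@@H](O)c2ccccc2)CO[C@@H]1c1ccccc1` gives 4990 nM, and compound 3 `O[C@@H](c1ccccc1)[C@H]1CO[C@H](c2ccccc2)[C@@H](C/C=C/c2cccc(F)c2)C1` gives 9170 nM. On these three numbers compound 3 stands second highest; its nearest neighbour is compound 2, within the scatter, while compound 1 lies beyond the scatter from it on the high side. Among the measured compounds shown here, the only single-point step known so far, a 1.8-fold higher number from compound 2 to compound 3 (0.26 log units; within the scatter), replaced hexyl by 3-fluorophenyl on a double-bonded chain carbon bound to a double-bonded chain carbon and stayed within the scatter.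

Compound 4 `Oc1ccc(/C=C/C[C@H]2C[C@@H]([C@@H](O)c3ccccc3)CO[C@@H]2c2ccccc2)cc1` is not yet measured. It differs from compound 3 by 4-hydroxyphenyl in place of 3-fluorophenyl on a double-bonded chain carbon bound to a double-bonded chain carbon. For the measured compounds named here, no measured step changes a substituent on that aryl ring. The step from compound 2 to compound 3 sits at the same position but swaps a chain for a ring, so it shows only that this end of the molecule tolerated a change without a shift beyond the scatter. Going by the values given here, compound 1 gives a higher number than compound 3 but differs from it in several places at once and yields no clean step. For compound 4 the expected step of a 1.1-fold lower number from compound 3 to compound 4 (0.03 log units; within the scatter) is therefore small, with no clear direction beyond the scatter. In this assay compound 4 is expected near 8500 nM, within a range from 3000 nM to 25000 nM.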

Compound 4, half-maximal inhibitory concentration: 7380 nM
Compound 4: the middle estimate sits 1.2-fold (0.06 log units) above what was measured, and the stated range covers the measured number.
By their numbers in this assay, from the lowest: compounds 2, 4 and 3 (each within the scatter of the next); then compound 1.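

Working notes, aryl end of the propenyl chain. In this assay, among the compounds shown here, this is the first step that keeps an aryl ring on a double-bonded chain carbon bound to a double-bonded chain carbon and changes only that ring: a 1.2-fold lower number from compound 3 to compound 4 (0.09 log units; within the scatter) brings in a hydrogen-bond donor and a hydrogen-bond acceptor that 3-fluorophenyl lacks, and the read-out gives no separation. Set against the hexyl chain, a 1.5-fold higher number from compound 2 to compound 4 (0.17 log units; within the scatter) matches the earlier result for 3-fluorophenyl, so hexyl, 3-fluorophenyl and 4-hydroxyphenyl cannot be told apart at this place in this assay, and tolerance here now covers three groups of differing kinds. No measurement at hand accounts for this tolerance.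

The swap from 3-fluorophenyl to 4-hydroxyphenyl alters both the substituent and its place on the ring at once, so the compounds shown do not separate those two changes, and 3-hydroxyphenyl or 4-fluorophenyl would be needed to do so. On these data alone, it also remains open whether an amine or a carboxylic acid on this ring, or a chain longer than hexyl, would produce a step beyond the scatter.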